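Swapping the Nitrogen Substituent: Compound 4 Expected Inactive

The source may report more compounds than this note shows. Statements on the series, on what has been measured and on what is new or still open speak of the compounds shown alone.

Compound 1 `C=CCNC(=O)n1c(-c2ccc(OC)cc2)cc(=O)c2c(OC)cc(OC)cc21`: > 20000 nM
Compound 2 `COc1ccc(-c2c(I)c(=O)c3c(OC)cc(OC)cc3n2S(=O)(=O)c2ccc(OC)cc2)cc1`: > 17300 nM
Compound 3 `COc1ccc(-c2cc(=O)c3c(OC)cc(OC)cc3n2S(=O)(=O)c2ccc(Cl)cc2)cc1`: > 34400 nM

In a functional assay on HepG2 cells (Homo sapiens) for antiproliferative activity, with a stated time of 72 h (on this read-out higher numbers stand for an effect only at larger amounts of compound and lower numbers for an effect already at smaller amounts), compound 1 gives > 20000 nM, which is a limit of the assay and not a number. Compound 2 gives > 17300 nM, likewise a limit. Compound 3 gives > 34400 nM, again a limit. Compound 1 therefore stands at a limit, as do the other two compounds, and none of them shows a readable effect.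

Compound 4 `COc1ccc(-c2cc(=O)c3c(OC)cc(OC)cc3n2S(=O)(=O)c2ccc(Br)cc2)cc1` differs from compound 1 by (4-bromophenyl)sulfonyl in place of allylcarbamoyl on an aromatic nitrogen. Going by the values given here, the only measured step that bears on this change is a step that the two limits leave unreadable from compound 1 to compound 3, and its size cannot be read, since both ends are limits. The three limits (the limit of > 17300 nM in this assay, at which 1 of the 3 values shown sits), the limit of > 20000 nM in this assay, at which 1 of the 3 values shown sits, and the limit of > 34400 nM in this assay, at which 1 of the 3 values shown sits, give no direction and no size beyond the scatter.

Compound 4 is therefore expected to sit at a limit as well, with an estimated 30000 nM (range 15000 nM to 100000 nM), and the expected step that the limit leaves unreadable from compound 1 to compound 4 is not readable.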

Compound 4, half-maximal effective concentration: 16300 nM
Compound 4: the middle estimate sits 1.8-fold (0.26 log units) above what was measured; measured number inside the range.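

In this assay, going by these compounds alone, compound 4 gives 16300 nM, the only value shown that is a number and not a limit of the assay, so steps can now be given at least a minimum size. On the aromatic nitrogen, (4-bromophenyl)sulfonyl in place of allylcarbamoyl gives an at least 1.2-fold lower number from compound 1 to compound 4 (0.08 log units; that floor lies within the scatter), so this comparison alone does not establish a change at that position. Bromo in place of chloro on an aromatic carbon gives an at least 2.1-fold lower number from compound 3 to compound 4 (0.32 log units; beyond the scatter), which makes this single swap the one step shown to go beyond the scatter.

On these data alone, the steps between compounds that both stand at limits cannot be read, so their sizes remain open. As far as these compounds go, it also remains open how far the number would move with fluoro, methoxy or an amine in place of bromo on that aromatic carbon.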